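Methylphenyl for bromophenyl on a weakly active compound

This account rests on a few compounds, and the source may have more. Where it says the series, first, only, none or still open, it means among the compounds named here.

In a functional assay on MV4-11 cells (Homo sapiens) for cytotoxicity, read by colorimetric assay and MTT assay, with a stated time of 3 days, tested at 20 uM (a lower number here means a stronger effect, a higher number a weaker effect of the compound at the concentration tested), the measured compounds are three:

Compound 1 `O=C1COc2ccc(-c3nn(-c4ccc(Br)cc4)cc3-c3ccccc3)cc2N1` gives 91.5%.
Compound 2 `O=C1COc2ccc(-c3[nH]c(-c4c[nH]c5ncccc45)nc3-c3ccccc3)cc2N1` gives 8.9%.
Compound 3 `O=C1COc2ccc(-c3[nH]c(-c4ccccc4)nc3-c3ccccc3)cc2N1` gives 7.6%.

On these numbers compound 1 stands highest of the three, that is, it shows the weakest effect; compound 2 is nearest to it and compound 3 furthest, both of them lower than compound 1 beyond the scatter. Compound 2 and compound 3 share a core of their own and the step between them, a number 1.3 percentage points lower from compound 2 to compound 3 (within the scatter), replaces a group of 9 heavy atoms with a phenyl group on an aromatic carbon; it lies within the scatter.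

Compound 4 `Cc1ccccc1-n1cc(-c2ccccc2)c(-c2ccc3c(c2)NC(=O)CO3)n1` is drawn from compound 1 by one change: 2-methylphenyl in place of 4-bromophenyl on an aromatic nitrogen. Among the compounds with values here, no measured step touches that position or that group: the only step recorded sits on a different core and on an aromatic carbon, so it gives no direct guidance here. With nothing to suggest a large move, the value of compound 4 in this assay is expected to stay close to that of compound 1, an expected step of a number 6.5 percentage points lower from compound 1 to compound 4 (within the scatter). Compound 4 is therefore estimated at 85%, within a range from 60% to 100%.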

Compound 4, a percentage reported as activity, at one concentration (the size of the read-out at that concentration, not a potency): 54.2%
For compound 4 the middle estimate is 30.8 percentage points above the measured one; the measured number lies below the stated range.
By their numbers in this assay, from the lowest: compounds 3 and 2 (each within the scatter of the next); then compound 4; then compound 1.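

In this assay, within the data shown here, putting 2-methylphenyl in place of 4-bromophenyl on the aromatic nitrogen gives a number 37.3 percentage points lower from compound 1 to compound 4 (beyond the scatter) and so shows that this position, which no earlier step touched, responds to the group it carries. The change is not registered by the counts for the two groups: both have the same number of heavy atoms, one six-membered aromatic ring of carbon only, no hydrogen-bond donors or acceptors and no net charge, so the difference lies in the swap of a bromine for a methyl and in where each sits on the ring. Nothing measured on these compounds speaks to the cause of this step.

The compounds shown leave open whether the step goes with the loss of the bromine, the arrival of the methyl or the new place of the substituent, since all of these change together in this one swap. A plain phenyl, 2-bromophenyl or 4-methylphenyl on the same nitrogen would pull these apart, and an amine or a carboxylic acid on that ring would show how far the position tolerates other kinds of group.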